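Freeing the Aromatic Amine on a Second Core

This account rests on a few compounds, and the source may have more. Where it says the series, first, only, none or still open, it means among the compounds named here.

Compound 1 `COc1ccc(C(=O)c2cc(OC)c(OC)c(OC)c2)cc1N` carries a free amino group on an aromatic ring. In a functional assay on HT-29 cells (Homo sapiens) for cytotoxicity, read by MTT assay, with a stated time of 72 h (a lower number here means a stronger inhibitor, a higher number a weaker inhibitor), compound 1 gives 50 nM. Compound 2 `COc1ccc(C(=O)c2cc(OC)c(OC)c(OC)c2)cc1NC(=O)/C=C/c1ccc(F)cc1` has that amine capped, and in this assay compound 2 gives 1800 nM. The structural difference between them is hydrogen in place of (2-(4-fluorophenyl)ethenyl)carbonyl on a nitrogen on an aromatic ring. The step this made was large: a 36-fold lower number from compound 2 to compound 1 (1.56 log units; beyond the scatter). Compound 3 `COc1cc(C(=O)c2cc(OC)c(OC)c(OC)c2)cc(NC(=O)/C=C/c2ccc(F)cc2)c1OC` has a different core, the difference being (methoxy in place of hydrogen on an aromatic carbon). In this assay compound 3 gives 1800 nM, and the core change showed no change at the digits printed from compound 2 to compound 3 (within the scatter). Compound 4 `COc1cc(C(=O)c2cc(OC)c(OC)c(OC)c2)cc(N)c1OC` differs from compound 3 by hydrogen in place of (2-(4-fluorophenyl)ethenyl)carbonyl on a nitrogen on an aromatic ring, the same change as before, at the same place. Because the earlier step was a 36-fold lower number from compound 2 to compound 1 (1.56 log units; beyond the scatter), and because the core change gave no change at the digits printed from compound 2 to compound 3 (within the scatter), compound 4 is expected to show a 30-fold lower number from compound 3 to compound 4 (1.48 log units; beyond the scatter). Compound 4 is therefore estimated at 60 nM, probably between 15 nM and 250 nM.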

Compound 4, half-maximal inhibitory concentration: 3800 nM
Compound 4: middle estimate off by 63-fold (1.80 log units), on the low side; the whole stated range lies below it.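

On the core of compound 3, putting hydrogen in place of (2-(4-fluorophenyl)ethenyl)carbonyl on the nitrogen gives a 2.1-fold higher number from compound 3 to compound 4 (0.32 log units; beyond the scatter) in this assay and so does not repeat the earlier step: the same change on two cores in this assay, a 36-fold lower number (1.56 log units; beyond the scatter) from compound 2 to compound 1 and a 2.1-fold higher number (0.32 log units; beyond the scatter) from compound 3 to compound 4, 76-fold (1.88 log units) apart, beyond the scatter of two such steps. With the free amine, methoxy in place of hydrogen gives a 76-fold higher number from compound 1 to compound 4 (1.88 log units; beyond the scatter) and so differs from the same change on the capped compounds: the same change on two cores in this assay, no change at the digits printed (within the scatter) from compound 2 to compound 3 and a 76-fold higher number (1.88 log units; beyond the scatter) from compound 1 to compound 4, 76-fold (1.88 log units) apart, beyond the scatter of two such steps. The two changes therefore cannot simply be added together across these cores, but these four compounds do not show why, nor how any other core would behave.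

Still open, from the compounds shown here alone, is how an acetyl or a methyl group on that nitrogen would behave on each core. Also open, going by these compounds, is whether an ethoxy or a hydroxyl group in place of the added methoxy would give as large a step from compound 1.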